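Methylsulfanyl in place of benzylamino on the shared core

The compounds below may be only part of what the source reports. "The series", "measured", "known", "first", "only" and "open" are said of these compounds alone.

Compound 1 `OC[C@H]1O[C@@H](n2cnc3c(NCc4ccccc4)nccc32)C[C@@H]1O` is the starting point. In a functional assay on EL4 cells (Mus musculus) for inhibition, tested at 100 uM (a lower number here means less inhibition, a higher number more inhibition at the concentration tested (going by the name of the read-out)), compound 1 gives 8%, the lowest of the two numbers available. The nearest number belongs to compound 3 `CN(C)c1[nH]ccc2ncnc1-2`, which in this assay gives 25%, a gap beyond the usual scatter. Compound 2 `CSc1nccc2c1ncn2C1O[C@H](CO)[C@@H](O)[C@H]1O` returns only a limit in this assay, < 5%, and not a number. The set therefore contains (the limit of < 5% in this assay, at which 1 of the 3 values shown sits).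

Compound 4 `CSc1nccc2c1ncn2[C@H]1C[C@H](O)[C@@H](CO)O1` has not yet been measured. It differs from compound 1 by methylsulfanyl in place of benzylamino on an aromatic carbon. Compound 2 carries the same methylsulfanyl group on a different core and sits at the limit, while compound 1 already lies low. For the measured compounds named here, no measured step isolates this change, so the expectation rests on those two values alone.

The expected step of a number 3 percentage points lower from compound 1 to compound 4 (within the scatter) is downward but small, within the scatter, with a real chance that only a limit is reported. Compound 4 is expected to give 5% in this assay, between 0% and 15%.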

Compound 4, a percentage reported as inhibition, at one concentration (the size of the read-out at that concentration, not a potency): < 5%
Compound 4 ended at the assay's limit; the forecaster's own chance of this, stated with the estimate: 50%; the middle value sits exactly at the limit.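

Compound 4 gives < 5% in this assay, which is a limit of the assay and not a number. For the compounds shown here, this is the first reading of the change on the shared core: methylsulfanyl in place of benzylamino on an aromatic carbon, next to the ring nitrogen, gives a number at least 3 percentage points lower from compound 1 to compound 4 (that floor lies within the scatter), so no drop beyond the scatter can be claimed, and the true size of the step stays hidden. Neither group lifts the read-out at this position, and this end of the series leaves little room for ranking: the limit of < 5% in this assay, at which 2 of the 4 values shown sit.

Still open, going by these compounds, is whether any group at this position can bring the read-out clear of the limit on this core. A plain amino group, a methoxy group or a longer chain ending in a carboxylic acid would each test that.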